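A few compounds are considered here, and "the series" means these few. Any claim that something is new, unique, unknown or untested is made for them only; others in the source may bear on it.

Notes on the series in a functional assay (aorta) with Oryctolagus cuniculus as the target; a lower number here means a stronger inhibitor, a higher number a weaker inhibitor: compound 1 `CC1=C(C)C(=O)C(C(CCCCCC(=O)O)c2ccc(C)cc2)=C(C)C1=O` gives 1000 nM, compound 2 `CC1=C(C)C(=O)C(C(CCCCCC(=O)O)c2ccccc2C)=C(C)C1=O` gives 3200 nM, and compound 3 `CC1=C(C)C(=O)C(C(CCCCCC(=O)O)c2ccc(Br)cc2)=C(C)C1=O` gives 1700 nM. Compound 3 stands within the scatter of both other numbers. The steps are a 1.7-fold higher number from compound 1 to compound 3 (0.23 log units; within the scatter) and a 1.9-fold lower number from compound 2 to compound 3 (0.27 log units; within the scatter). The largest change at this place is a 3.2-fold higher number from compound 1 to compound 2 (0.51 log units; beyond the scatter). Compound 4 `CC1=C(C)C(=O)C(C(CCCCCC(=O)O)c2cccs2)=C(C)C1=O` carries thiophen-2-yl in place of 4-bromophenyl, on a saturated chain carbon bound to a double-bonded ring carbon and a saturated chain carbon (thiophen-2-yl in place of 4-bromophenyl on a saturated chain carbon bound to a double-bonded ring carbon and a saturated chain carbon). For the measured compounds named here, no measured compound carries thiophen-2-yl, so these steps bear on it only indirectly, and they stay modest. The expected result is a 1.1-fold higher number from compound 3 to compound 4 (0.02 log units; within the scatter), with no step beyond the scatter anticipated. For compound 4 the estimated value is 1800 nM, within an expected range of 700 nM to 4500 nM.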

Compound 4, half-maximal inhibitory concentration: 760 nM
Estimate against measurement, compound 4: 2.4-fold (0.37 log units) above, within the range that was stated.
By their numbers in this assay, from the lowest: compounds 4, 1, 3 and 2 (each within the scatter of the next, the first and the last beyond it).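

In this assay thiophen-2-yl at this place gives a 2.2-fold lower number from compound 3 to compound 4 (0.35 log units; beyond the scatter) and a 4.2-fold lower number from compound 2 to compound 4 (0.62 log units; beyond the scatter) and so shows that the group here need not be a six-membered aromatic ring of carbon only. Against 4-methylphenyl the change reads a 1.3-fold lower number from compound 1 to compound 4 (0.12 log units; within the scatter) and leaves compound 1 and compound 4 without an order. Nothing at hand gives a reason for these steps.

On these data alone, whether the number of compound 4 holds with a furan ring or a pyridine ring at this place remains open. As far as these compounds go, a saturated cyclohexyl group at the same carbon also remains open.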